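The source may report more compounds than this note shows. Statements on the series, on what has been measured and on what is new or still open speak of the compounds shown alone.

Compound 1, `N#C[C@@H]1CCCN1C(=O)[C@@H]1C[C@H](CO)CN1`, in an assay on the whole organism (plasma, strain Sprague-Dawley) for inhibition of Dipeptidyl peptidase 4 (Rattus norvegicus), with a stated time of 6 h, at a dose of 1 mg/kg by the oral route; on this read-out higher numbers stand for more inhibition at the one dose given (going by the name of the read-out) and lower numbers for less inhibition: 64%
Compound 2, `CCCNC(=O)[C@@H]1CN[C@H](C(=O)N2CCC[C@H]2C#N)C1`, in this assay: 59%

Within the data shown here, of these two numbers, the one for compound 2 is the smaller, but the step of a number 5 percentage points lower from compound 1 to compound 2 (within the scatter) lies within the scatter, so the two compounds are not told apart. Compound 3, `CN(C)C(=O)[C@@H]1CN[C@H](C(=O)N2CCC[C@H]2C#N)C1`, differs from compound 2 by dimethylamino in place of propylamino on a carbonyl carbon; read one bond further out, propylcarbamoyl gives way to dimethylcarbamoyl. Among the measured compounds shown here, the only measured step, from hydroxymethyl to propylcarbamoyl, was small, and no measured step exchanges one amino group for another. The expected step is therefore a number 3 percentage points lower from compound 2 to compound 3 (within the scatter), nothing beyond the scatter. Compound 3 is estimated at 56%, between 36% and 76%.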

Compound 3, a percentage reported as inhibition, in the whole organism at one dose (the size of the read-out at that dose, not a potency): 76%
Compound 3: the middle estimate sits 20 percentage points below what was measured; the measured number falls inside the stated range.
By their numbers in this assay, from the lowest: compounds 2 and 1 (each within the scatter of the next); then compound 3.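

On the carbonyl carbon the choice of amino group does count in this assay: dimethylamino in place of propylamino gives a number 17 percentage points higher from compound 2 to compound 3 (beyond the scatter) and so separates two amides, which the earlier pair could not show. Dimethylcarbamoyl in place of hydroxymethyl on the saturated ring carbon gives a number 12 percentage points higher from compound 1 to compound 3 (beyond the scatter) as well, whereas propylcarbamoyl stayed within the scatter of hydroxymethyl. No measured evidence here accounts for this difference. Open, from the compounds shown here alone, is whether methylamino or a ring amine such as morpholine on that carbonyl would match dimethylamino, and how a carboxylic acid there would compare.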